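A few compounds are considered here, and "the series" means these few. Any claim that something is new, unique, unknown or untested is made for them only; others in the source may bear on it.

Measured in an ADME assay on L6 cells (Rattus norvegicus) for cytotoxicity, read by resazurin assay, with a stated time of 72 h; on this read-out higher numbers stand for weaker inhibition and lower numbers for stronger inhibition:
Compound 1 `OC(c1ccc(Cl)cc1)(c1ccc(Br)cc1)c1cccnc1`: 57000 nM
Compound 2 `OC(c1ccc(Cl)cc1)(c1ccncn1)c1ccccc1Cl`: > 100000 nM, which is a limit
Compound 3 `OC(c1ccc(Br)cc1)(c1ccc(C(F)(F)F)cc1)c1cccnc1`: 54700 nM

Compound 3 stands level with compound 1 within the scatter, and the only other result is the limit for compound 2. Compound 4 `N#Cc1ccc(C(O)(c2ccc(C(F)(F)F)cc2)c2cccnc2)cc1` carries cyano in place of bromo on an aromatic carbon. Among the compounds with values here, no measured step replaces bromo. The closest is a 1.0-fold lower number from compound 1 to compound 3 (0.02 log units; within the scatter), which put trifluoromethyl in place of chloro on an aromatic carbon and stayed within the scatter. In this assay, no step beyond the scatter is therefore expected, and the estimate is a 1.2-fold higher number from compound 3 to compound 4 (0.07 log units; within the scatter). Compound 4 is expected at 65000 nM, with an estimated range of 28000 nM to 100000 nM.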

Compound 4, half-maximal inhibitory concentration: 76500 nM
Beside the measured number, compound 4's estimate is 1.2-fold (0.07 log units) below it; the range from low to high includes it.
By their numbers in this assay, from the lowest: compounds 3, 1 and 4 (each within the scatter of the next). At a limit, above all of these: compound 2.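

In this assay, the first replacement of bromo shown, on an aromatic carbon para to a large group, gives a 1.4-fold higher number from compound 3 to compound 4 (0.15 log units; within the scatter) and so no step beyond the scatter at this position. Within the data shown here, the earlier step changed chloro only, so this is the first sign that the 4-bromophenyl position also accepts a different group, here 4-cyanophenyl, without a clear shift in the number. The compounds shown leave open whether an amine or a carboxylic acid on this carbon would give a step beyond the scatter. Nothing given here bears on why this change stays within the scatter.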